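Cyclopropyl to hydrogen on an aromatic nitrogen: compound 3

The source may hold more compounds than are shown below. What is called first, only, known or untested is meant among the compounds shown, and "the series" means these compounds.

Measured in an ADME assay on microsomes from liver (Homo sapiens) for metabolic stability, read by LC-MS, using NADPH, with a stated time of 30 min, tested at 1.5 uM (on this read-out higher numbers stand for a more stable compound and lower numbers for a less stable compound), so far:
compound 1 `N#Cc1cc(Nc2nc(N)nc(-c3cccc(-n4ccc5cc(C6CC6)cc(F)c5c4=O)c3CO)n2)cn1C1CC1` gives 69%
compound 2 `Nc1nc(Nc2cnn(C3CC3)c2)nc(-c2cccc(-n3ccc4cc(C5CC5)cc(F)c4c3=O)c2CO)n1` gives 79%

Compound 2 stands at 79% and compound 1 at 69%. For the measured compounds named here, the single measured step, a number 10 percentage points higher from compound 1 to compound 2 (within the scatter), lies within the scatter, so the two compounds are not separated by this assay; compound 2 is simply the one with the number from which the next step departs.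

Compound 3 `Nc1nc(Nc2cn[nH]c2)nc(-c2cccc(-n3ccc4cc(C5CC5)cc(F)c4c3=O)c2CO)n1` differs from compound 2 by hydrogen in place of cyclopropyl on an aromatic nitrogen. Going by the values given here, the one measured step does not bear on this change: it exchanged the whole five-membered ring while the cyclopropyl on the ring nitrogen was kept in both compound 1 and compound 2. Among the compounds with values here, nothing measured here therefore speaks to the loss of that cyclopropyl, and the expectation rests only on the size of the one known step, which was small.

For compound 3 the step of a number 7 percentage points lower from compound 2 to compound 3 (within the scatter) is expected to be small, without a clear direction. Compound 3 is estimated at 72%, with a range from 50% to 90% in this assay.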

Compound 3, percent of the compound remaining in the Homo sapiens assay: 100%
Compound 3: middle estimate off by 28 percentage points, on the low side; measured number outside the range, above it.
By their numbers in the Homo sapiens assay, from the lowest: compounds 1 and 2 (each within the scatter of the next); then compound 3.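

In the Homo sapiens assay the aromatic nitrogen of the pyrazole proves to be a position that separates compounds: hydrogen in place of cyclopropyl gives a number 21 percentage points higher from compound 2 to compound 3 (beyond the scatter), whereas the exchange of the whole five-membered ring with the cyclopropyl kept had stayed inside the scatter. Against the 5-cyano-1-cyclopropyl-1H-pyrrol-3-yl group, the 1H-pyrazol-4-yl group in the Homo sapiens assay gives a number 31 percentage points higher from compound 1 to compound 3 (beyond the scatter), so compound 3 now stands clear of both earlier compounds. In a physicochemical assay for solubility, read by LC-MS, measured as kinetic solubility, with a stated time of 1 h (a higher number here means a more soluble compound, a lower number a less soluble compound), compound 2 gives 4700 nM and compound 3 gives 12000 nM. In the physicochemical assay the loss of the cyclopropyl also goes with a higher number, so at this position the two read-outs move the same way for this one pair: the measured solubility of compound 2, 4700 nM, and of compound 3, 12000 nM, a 2.6-fold higher number (0.41 log units; beyond the scatter)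

With only cyclopropyl and hydrogen shown on this nitrogen, the compounds cannot tell whether the higher numbers go with the loss of the three-membered ring or with the free hydrogen on the ring nitrogen. A methyl group, or a short chain ending in a hydroxyl, on the same nitrogen would remove the three-membered ring while keeping the nitrogen substituted, and so would separate these two readings.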